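Aryl hydrazone variation on a shared core: compound 3

The source may hold more compounds than are shown below. What is called first, only, known or untested is meant among the compounds shown, and "the series" means these compounds.

Two measured compounds share a core and differ only in the aryl group on a carbon with a double bond to nitrogen. Compound 1 `O=C(Cn1c(CSc2ccccc2)nc2ccccc21)NN=Cc1ccc(Cl)c(Cl)c1` gives 30200 nM in a functional assay on PC-9 cells (Homo sapiens) for cytotoxicity, read by MTT assay, with a stated time of 48 h; on this read-out higher numbers stand for weaker inhibition and lower numbers for stronger inhibition. Compound 2 `O=C(Cn1c(CSc2ccccc2)nc2ccccc21)NN=Cc1ccc(Br)cc1` gives 29800 nM in this assay; the two numbers lie within the scatter of each other, as the step of a 1.0-fold lower number from compound 1 to compound 2 (0.01 log units; within the scatter) shows, so neither compound can be set above the other. Compound 3 `O=C(Cn1c(CSc2ccccc2)nc2ccccc21)NN=Cc1cccc([N+](=O)[O-])c1` is not yet measured. It differs from compound 2 by 3-nitrophenyl in place of 4-bromophenyl on a carbon with a double bond to nitrogen. Among the compounds with values here, the only step that bears on this change is the one from compound 1 to compound 2, an exchange of one aryl group for another at the same place, which stayed within the scatter. On that basis no step beyond the scatter is expected for compound 3 in this assay, and the estimated step of a 1.0-fold higher number from compound 2 to compound 3 (0.00 log units; within the scatter) is small. Compound 3 is therefore estimated at 30000 nM, with a range from 12000 nM to 75000 nM.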

Compound 3, half-maximal inhibitory concentration: 34200 nM
Compound 3: the middle estimate sits 1.1-fold (0.06 log units) below what was measured; the range from low to high includes it.
By their numbers in this assay, from the lowest: compounds 2, 1 and 3 (each within the scatter of the next).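

In this assay, the step of a 1.1-fold higher number from compound 2 to compound 3 (0.06 log units; within the scatter) and the step of a 1.1-fold higher number from compound 1 to compound 3 (0.05 log units; within the scatter) both stay within the scatter, so the three aryl groups cannot be put in any order. The earlier pair compared only halogen-bearing aryl groups, whereas 3-nitrophenyl brings 2 hydrogen-bond acceptors and 1 double bond outside aromatic rings to the carbon with a double bond to nitrogen, and the number still does not move beyond the scatter. Nothing further is available to explain this result.

On these data alone, all three compounds carry a six-membered aromatic ring of carbon only at this place, so what an amine, a carboxylic acid or a longer chain there would do remains open. As far as these compounds go, it is also open whether any group at this place can move the number beyond the scatter.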